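Thiazole in Place of Benzothiazole on the Shared Core

The source may hold more compounds than are shown below. What is called first, only, known or untested is meant among the compounds shown, and "the series" means these compounds.

Of the compounds shown here, three have been measured in a functional assay on KYSE-70 cells for antiproliferative activity against KYSE-70 cell line (Homo sapiens), read by MTT assay, with a stated time of 72 h; on this read-out lower numbers stand for stronger inhibition and higher numbers for weaker inhibition. Compound 1 `C#CCSc1nc(Sc2nnnn2CCN(C)C)c(C#N)c(-c2cccc(Cl)c2)n1` gives 5320 nM in this assay. Compound 3 `C=CC(=O)Nc1ccccc1CN(C(=O)Nc1cccc(C(F)(F)F)c1)C1CCN(C(C)CCC)CC1` gives 17900 nM in this assay. Compound 2 `C#CCSc1nc(Sc2nc3ccccc3s2)c(C#N)c(-c2cc(OC)c(OC)c(OC)c2)n1` returns no number in this assay but only a limit, > 20000 nM, so where it stands among the three is known only to that extent; the same is recorded as the limit of > 20000 nM in this assay, at which 1 of the 3 values shown sits. Compound 4 `C#CCSc1nc(Sc2nc(C)c(C)s2)c(C#N)c(-c2cc(OC)c(OC)c(OC)c2)n1` has not yet been measured in this assay. It differs from compound 2 in one place: 4,5-dimethyl-1,3-thiazol-2-yl in place of 1,3-benzothiazol-2-yl on a sulfur. Everything else in the structure of compound 2 is kept. For the measured compounds named here, no step between two measured compounds is available, so the size of this change cannot be read from a measured pair. With compound 2 standing at a limit and the shared core unchanged, compound 4 is expected to stay weak in this assay, and the expected step of a number no higher from compound 2 to compound 4 (the limit leaves the size open) is none beyond the scatter. The estimate for compound 4 is 20000 nM, expected between 8000 nM and 40000 nM, with a real chance that this assay again reports only a limit.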

Compound 4, half-maximal inhibitory concentration: > 20000 nM
Compound 4: only a limit was reported; the forecaster's own chance of this, stated with the estimate: 55%; the middle value lies on the limit itself.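

For the compounds shown here, compound 2 and compound 4 each return only a limit in this assay, so no step between them can be read: the limit of > 20000 nM in this assay, at which 2 of the 4 values shown sit. The compounds shown leave open whether 4,5-dimethyl-1,3-thiazol-2-yl and 1,3-benzothiazol-2-yl on a sulfur differ at all in this assay.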